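The source may report more compounds than this note shows. Statements on the series, on what has been measured and on what is new or still open speak of the compounds shown alone.

Compound 1 `Clc1ncc(OC[C@@H]2CCCN2)cc1-c1cccnc1`: 0.021 nM
Compound 2 `Fc1ccc(-c2cc(OC[C@@H]3CCN3)cnc2Cl)cn1`: 0.0049 nM
Compound 3 `Clc1ncc(OC[C@@H]2CCN2)cc1-c1ccc(Br)nc1`: 0.0043 nM

All three were tested in an assay on membranes from brain with Neuronal acetylcholine receptor; alpha4/beta2 (Rattus norvegicus) as the target; a lower number here means a stronger inhibitor, a higher number a weaker inhibitor. Compound 2 stands second highest of the three numbers; its nearest neighbour is compound 3, and the step of a 1.1-fold lower number from compound 2 to compound 3 (0.06 log units; within the scatter) lies within the scatter. Compound 1 is furthest away, with a higher number than compound 2, a gap beyond the scatter. Compound 1 and compound 2 differ in two places. Within the data shown here, no measured pair separates those two changes from each other.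

Compound 4 `Fc1ccc(-c2cc(OC[C@@H]3CCCN3)cnc2Cl)cn1` is not yet measured. It differs from compound 2 in one place: pyrrolidin-2-yl in place of azetidin-2-yl on a saturated chain carbon bound to an oxygen on an aromatic ring. Among the measured compounds shown here, no measured pair shows this ring change on its own. For the measured compounds named here, the only measured step, a 1.1-fold lower number from compound 2 to compound 3 (0.06 log units; within the scatter), concerns a different part of the molecule and says nothing about the ring. The values of compound 1 and compound 2 only hint that the compound carrying the pyrrolidine ring sits at a higher number in this assay, but that hint is confounded by the second difference.

For compound 4 a modestly higher number than compound 2 is therefore expected, a 2.4-fold higher number from compound 2 to compound 4 (0.39 log units; beyond the scatter), with wide uncertainty. The estimate for compound 4 is 0.012 nM, expected to fall between 0.004 nM and 0.04 nM.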

Compound 4, inhibition constant: 0.0179 nM
Beside the measured number, compound 4's estimate is 1.5-fold (0.17 log units) below it; measured number inside the range.
By their numbers in this assay, from the lowest: compounds 3 and 2 (each within the scatter of the next); then compounds 4 and 1 (each within the scatter of the next).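

In this assay, among these compounds, the step of a 3.7-fold higher number from compound 2 to compound 4 (0.56 log units; beyond the scatter) shows the ring change on its own for the first time: with pyrrolidin-2-yl in place of azetidin-2-yl on the saturated chain carbon bound to an oxygen on an aromatic ring, the number rises by more than the scatter, though the step is modest in size. The second step, a 1.2-fold lower number from compound 1 to compound 4 (0.07 log units; within the scatter), shows that fluoro in place of hydrogen on an aromatic carbon makes no readable difference when the pyrrolidine ring is present, so the two changes that could not be told apart earlier now separate, and only the ring change gives a step beyond the scatter. No evidence is available on why this ring change shifts the number.

The compounds shown leave open how piperidin-2-yl would read on the same saturated chain carbon, so two ring sizes do not yet make a trend. From the compounds shown here alone, it also remains open whether the ring step keeps its size when bromo takes the place of fluoro on the aromatic carbon.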